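From compound 3 to compound 4 in K562 cells

A few compounds are considered here, and "the series" means these few. Any claim that something is new, unique, unknown or untested is made for them only; others in the source may bear on it.

Values measured so far in a functional assay on K562 cells (Homo sapiens) for cytotoxicity, with a stated time of 72 h (a higher number here means a weaker inhibitor, a lower number a stronger inhibitor), are these

Compound 1 `CC1c2c(-c3ccncc3)c(-c3ccccc3C#N)nn2CC1(C)C` gives 77000 nM
Compound 2 `Cc1cccc(-c2nn3c(c2-c2ccnc(Nc4ccc(S(N)(=O)=O)cc4)c2)C(C)C(C)(C)C3)n1` gives 31000 nM
Compound 3 `CCc1cccc(-c2nn3c(c2-c2ccncc2)C(C)C(C)(C)C3)n1` gives > 100000 nM as a limit

Compound 3 has no exact number (its place is the limit of > 100000 nM in this assay, at which 1 of the 3 values shown sits) and so offers only a bound as a starting point. Compound 4 `CCc1cccc(-c2nn3c(c2-c2ccnc(Nc4ccc(S(N)(=O)=O)cc4)c2)C(C)C(C)(C)C3)n1` has not yet been measured. The change from compound 3 to compound 4 is (4-sulfamoylphenyl)amino in place of hydrogen on an aromatic carbon and puts (4-sulfamoylphenyl)amino in place of hydrogen on an aromatic carbon, next to the ring nitrogen. Among the measured compounds shown here, the only measured step (an at least 1.2-fold higher number from compound 1 to compound 3 (0.11 log units; that floor lies within the scatter)) concerns a different place and a different group, so it does not size this change. Closer guidance comes from compound 2, which carries the same (4-sulfamoylphenyl)amino group and gives 31000 nM in this assay as a true number. Resting on compound 2 at 31000 nM as the nearest reading, a move towards a lower number, meaning a stronger inhibitor, is expected. The expected size of the change is an at least 3.3-fold lower number from compound 3 to compound 4 (0.52 log units; beyond the scatter) on present evidence. For compound 4 the estimated value is 30000 nM with an expected range from 12000 nM to 80000 nM at this stage.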

Compound 4, half-maximal inhibitory concentration: 24000 nM
Beside the measured number, compound 4's estimate is 1.3-fold (0.10 log units) above it; low and high end bracket the measured number.
By their numbers in this assay, from the lowest: compounds 4 and 2 (each within the scatter of the next); then compound 1. At a limit, above all of these: compound 3.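

In this assay, among the compounds shown here, the step of an at least 4.1-fold lower number from compound 3 to compound 4 (0.61 log units; beyond the scatter) gives the first reading of what (4-sulfamoylphenyl)amino does on this aromatic carbon, next to the ring nitrogen, with the rest of the compound unchanged: the number moves beyond the scatter, which compound 2 alone could not show. This step is only a floor on the true size, since compound 3 stands at a limit and not at a number: the limit of > 100000 nM in this assay, at which 1 of the 4 values shown sits. With this group in place, the step of a 1.3-fold lower number from compound 2 to compound 4 (0.11 log units; within the scatter) lies within the scatter, so methyl in place of hydrogen on the saturated chain carbon bound to an aromatic carbon, which separates the ethyl of compound 4 from the methyl of compound 2, leaves no readable mark on the number in this assay.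

The compounds shown leave open which part of the entering group carries the step, for instance whether a plain amine on the same carbon, or a carboxylic acid in place of the sulfonamide on the phenyl ring, would give a similar number. They also leave open whether the same group would move the number as far on the core of compound 1, which carries 2-cyanophenyl.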